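A Methyl Added Where the Chain Carbons Meet

This account rests on a few compounds, and the source may have more. Where it says the series, first, only, none or still open, it means among the compounds named here.

Of the compounds shown here, three sharing one core have been tested in an ADME assay on HEL cells (Homo sapiens) for cytotoxicity, with a stated time of 3 days; a lower number here means that less compound is tolerated, a higher number that more compound is tolerated. Compound 1, `O=S1(=O)C=C(OCc2ccccc2)C(Cc2ccccc2)(Cc2ccccc2)O1`, gives 200000 nM. Compound 2, `CC1(Cc2ccccc2)OS(=O)(=O)C=C1OCc1ccccc1`, reaches > 400000 nM, which is a limit of the assay and not a number. Compound 3, `CCCC1(Cc2ccccc2)OS(=O)(=O)C=C1OCc1ccccc1`, reaches >= 400000 nM, also a limit rather than a number. The two changes that are readable, an at least 2.0-fold higher number from compound 1 to compound 2 (0.30 log units; that floor lies within the scatter) and an at least 2.0-fold higher number from compound 1 to compound 3 (0.30 log units; that floor lies within the scatter), each replace a phenyl and only reach a floor, and the closer change, a step that the two limits leave unreadable from compound 2 to compound 3, cannot be sized because both of its ends are limits. Compound 3 thus stands at the top of the measured range, fixed only by a limit.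

Compound 4, `CC(C)CC1(Cc2ccccc2)OS(=O)(=O)C=C1OCc1ccccc1`, differs from compound 3 by methyl in place of hydrogen on a saturated chain carbon bound to two saturated chain carbons. Going by the values given here, no measured step resolves a change of this kind, so no shift beyond the scatter is expected, and the step is estimated as a number no higher from compound 3 to compound 4 (the limit leaves the size open). Compound 4 is therefore expected to show about 400000 nM in this assay, within a range of 200000 nM to 800000 nM, most likely again reported as a limit.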

Compound 4, minimum cytotoxic concentration: >= 80000 nM
Compound 4 ended at the assay's limit; the forecaster's own chance of this, stated with the estimate: 70%; the middle value lies beyond the limit too.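

In this assay compound 4 gives >= 80000 nM, which is a limit and not a number, so its steps from compound 1, compound 2 and compound 3 cannot be read. The compounds shown leave open whether going from propyl to isobutyl changes the tolerated concentration at all.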